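Hormone-sensitive lipase inhibitors: isobutyl to tert-butyl

The source may report more compounds than this note shows. Statements on the series, on what has been measured and on what is new or still open speak of the compounds shown alone.

Measured so far:
compound 1 `Cc1c(C)n(C(=O)N2CCCCC2)oc1=O`: 13 nM in an assay (strain Wistar) for inhibition of Hormone-sensitive lipase (Rattus norvegicus), read by spectrophotometry; on this read-out higher numbers stand for weaker inhibition and lower numbers for stronger inhibition
compound 2 `Cc1c(CC(C)C)c(=O)on1C(=O)N1CCCCC1`: 5 nM in this assay

In this assay compound 2 gives 5 nM and stands lowest of the two numbers; its nearest neighbour is compound 1 with 13 nM. For the measured compounds named here, the single measured step, a 2.6-fold lower number from compound 1 to compound 2 (0.41 log units; beyond the scatter), added an isopropyl on a saturated chain carbon bound to an aromatic carbon, a modest gain.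

Compound 3 `Cc1c(C(C)(C)C)c(=O)on1C(=O)N1CCCCC1` has not yet been measured. Relative to compound 2 the change is tert-butyl in place of isobutyl on an aromatic carbon; the two compounds have the same atoms, joined differently. Going by the values given here, no measured step rearranges a group already in place, so the step from compound 1 to compound 2 bears on this only loosely: it shows that building out this position is tolerated, not how a different branching is received. The expectation is therefore for no step beyond the scatter in this assay, in either direction.

Compound 3 is estimated at 6 nM, with a range from 2 nM to 20 nM. The expected step is a 1.2-fold higher number from compound 2 to compound 3 (0.08 log units; within the scatter), within the scatter.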

Compound 3, half-maximal inhibitory concentration: 14 nM
For compound 3 the middle estimate is 2.3-fold (0.37 log units) below the measured one, and the stated range covers the measured number.
By their numbers in this assay, from the lowest: compound 2; then compounds 1 and 3 (each within the scatter of the next).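

In this assay, swapping isobutyl for tert-butyl on the aromatic carbon gives a 2.8-fold higher number from compound 2 to compound 3 (0.45 log units; beyond the scatter), so this position distinguishes two groups with the same count of heavy atoms and responds to how they are joined, not to that count alone. Tert-butyl in place of methyl gives a 1.1-fold higher number from compound 1 to compound 3 (0.03 log units; within the scatter), which is within the scatter, so the gain seen with isobutyl does not carry over to every larger carbon group at this position, and compound 3 is not separated from compound 1. Nothing available gives a reason for the difference between the two branched groups.

Still open, on these data alone, is how the position receives other carbon groups, such as a straight n-butyl chain, a longer n-hexyl chain or a cyclopropylmethyl group, which would show whether isobutyl is a local optimum or one point on a broader trend. Also open, as far as these compounds go, is whether a group carrying a heteroatom, such as an amine or a carboxylic acid, is accepted here, and whether the isobutyl over tert-butyl order holds when the group of 8 heavy atoms on the ring is replaced.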